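From tert-butyl to methoxy on the shared core

This account rests on a few compounds, and the source may have more. Where it says the series, first, only, none or still open, it means among the compounds named here.

Compound 1 `Cc1cc(NC(=O)Nc2ccccc2C(C)(C)C)c2ccccc2n1` is the starting point for this step. In an ADME assay on Raji cells (Homo sapiens) for cytotoxicity, with a stated time of 72 h (on this read-out higher numbers stand for an effect only at larger amounts of compound and lower numbers for an effect already at smaller amounts), compound 1 gives > 25000 nM, which is a limit of the assay and not a number. In this assay compound 2 `Cc1cc(NC(=O)Nc2ccc(O)cc2)c2ccccc2n1` gives > 25000 nM, which is also a limit. Neither compound therefore has a numerical value, and compound 1 stands at the limit of > 25000 nM in this assay, at which 2 of the 2 values shown sit.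

Compound 3 `COc1ccccc1NC(=O)Nc1cc(C)nc2ccccc12` carries methoxy in place of tert-butyl on an aromatic carbon, ortho to a large group: methoxy in place of tert-butyl on an aromatic carbon. Among the measured compounds shown here, the series offers no measured step between compounds that differ in one place, so the size of this change cannot be read from direct precedent. For compound 3 the expectation in this assay is no step beyond the scatter in either direction, since compound 1 stands at the limit of > 25000 nM in this assay, at which 2 of the 2 values shown sit. A report of compound 3 as a limit is also likely.

The expected change is a number no higher from compound 1 to compound 3 (the limit leaves the size open). Compound 3 is estimated at 25000 nM, with an expected range from 10000 nM to 50000 nM.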

Compound 3, half-maximal effective concentration: > 25000 nM
Compound 3: no number, only a limit; the forecaster's own chance of this, stated with the estimate: 80%; the middle value sits exactly at the limit.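

No step can be read between compound 1 and compound 3, as both are reported only as limits in this assay, and not as numbers: the limit of > 25000 nM in this assay, at which 3 of the 3 values shown sit.

The compounds shown leave open how methoxy and tert-butyl compare in this assay, and whether any change on the shared core gives a numerical value there.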